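The compounds below may be only part of what the source reports. "The series", "measured", "known", "first", "only" and "open" are said of these compounds alone.

Of the compounds shown here, three have been measured in a toxicity assay on the whole organism (strain Icem-CET (SPF Caw)) for cytotoxicity, with Mus musculus as the target; a higher number here means that more compound is needed for the effect, a lower number that less compound is needed. Compound 1 `C/C(C(=O)NC1CC1)=C(\C)c1ccccc1` gives 400 mg/kg in this assay. Compound 2 `C/C(C(=O)NC1CC1)=C(\C)c1ccc(Cl)cc1` gives 170 mg/kg in this assay, and compound 3 `C=CCNC(=O)/C(C)=C(\C)c1ccc(Cl)cc1` gives 70 mg/kg in this assay, which is the lowest of the three numbers, with compound 2 nearest to it and compound 1 furthest away.

Compound 2 and compound 1 differ in a single place: hydrogen in place of chloro on an aromatic carbon. This one change produced a 2.4-fold higher number from compound 2 to compound 1 (0.37 log units; beyond the scatter). Compound 3 and compound 2 are built from the same atoms joined differently; the difference between their two cores is not broken down here.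

Compound 4 `C=CCNC(=O)/C(C)=C(\C)c1ccccc1` has not yet been measured in this assay. It is related to compound 3 by the same change that relates compound 1 to compound 2: hydrogen in place of chloro on an aromatic carbon. The change sits in the same kind of position in both pairs, so the earlier step is the best guide available. Because the earlier step was a 2.4-fold higher number from compound 2 to compound 1 (0.37 log units; beyond the scatter), a step of comparable size is expected for compound 3 when it becomes compound 4. For compound 4 the expected step is a 2.4-fold higher number from compound 3 to compound 4 (0.39 log units; beyond the scatter). Compound 4 is therefore estimated at 170 mg/kg in this assay. Among the measured compounds shown here, for compound 4 the likely range runs from 90 mg/kg to 320 mg/kg, allowing for the usual scatter and for the fact that only one earlier step of this kind is known.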

Compound 4, dose for half-maximal effect: 130 mg/kg
Compound 4: middle estimate off by 1.3-fold (0.12 log units), on the high side, and the stated range covers the measured number.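

On the second core, putting hydrogen in place of the chloro on the aromatic carbon gives a 1.9-fold higher number from compound 3 to compound 4 (0.27 log units; within the scatter) in this assay. Set beside the earlier step, the new one agrees with it in size, so within these four compounds the effect of this change carries over from one core to the other with no difference that can be told apart: the same change on two cores in this assay, a 2.4-fold higher number (0.37 log units; beyond the scatter) from compound 2 to compound 1 and a 1.9-fold higher number (0.27 log units; within the scatter) from compound 3 to compound 4, 1.3-fold (0.10 log units) apart, within the scatter of two such steps. Among the compounds shown here, this rests on only two pairs, and the new step taken alone lies within the scatter, so it shows agreement between two cores but neither proves a firm rule for the whole series nor explains why the change acts as it does.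

The compounds shown leave open how other groups on that same aromatic carbon, such as bromo, methoxy or an amine, would compare with chloro and hydrogen. They also leave open whether a step of this size would hold on a core with a longer chain on the amide nitrogen, or with the chloro placed elsewhere on the ring.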